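Methylsulfanyl in place of isopropoxy: notes toward compound 4

The source may hold more compounds than are shown below. What is called first, only, known or untested is meant among the compounds shown, and "the series" means these compounds.

Compound 1 `COc1cc(-n2ncnc2-c2ccc(OC(C)C)cc2)cc(OC)c1OC` carries isopropoxy on the aryl ring attached to the shared core. In a functional assay on A549 cells (Homo sapiens) for antiproliferative activity, read by MTT assay, with a stated time of 72 h (on this read-out lower numbers stand for stronger inhibition and higher numbers for weaker inhibition), compound 1 gives > 10000 nM, which is a limit of the assay and not a number, so compound 1 cannot be placed relative to its neighbours. Compound 2 `COc1cc(-c2ncnn2-c2ccccc2)cc(OC)c1OC` in this assay gives > 10000 nM, also a limit. Compound 3 `COc1cc(-c2ncnn2-c2ccc(N)cc2)cc(OC)c1OC` in this assay gives > 10000 nM, again a limit. Among the compounds with values here, the single one-place step among them, a step that the two limits leave unreadable from compound 2 to compound 3, cannot be read because both ends sit at the limit of > 10000 nM in this assay, at which 3 of the 3 values shown sit. Compound 4 `COc1cc(-n2ncnc2-c2ccc(SC)cc2)cc(OC)c1OC` differs from compound 1 by methylsulfanyl in place of isopropoxy on an aromatic carbon. Within the data shown here, no measured step bears on this exchange, and the set as a whole yields only limits, so neither size nor direction can be drawn from it. Compound 4 is therefore expected near the limit, estimated at 15000 nM with a range from 4000 nM to 50000 nM. The step that the limit leaves unreadable from compound 1 to compound 4 that this estimate means is expected to stay within the scatter, with a readable number unlikely.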

Compound 4, half-maximal inhibitory concentration: 800 nM
Compound 4: the middle estimate sits 19-fold (1.27 log units) above what was measured; the measured number lies below the stated range.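

In this assay, methylsulfanyl in place of isopropoxy on an aromatic carbon, para to a large group, gives an at least 12-fold lower number from compound 1 to compound 4 (1.09 log units; beyond the scatter) on the shared core. Within the data shown here, this is the first step with a readable direction, and it shows that an exchange at this one position can carry the read-out from a limit of the assay to a number. Among these compounds, compound 4 is the only compound here with such a number, the others sitting at one limit: the limit of > 10000 nM in this assay, at which 3 of the 4 values shown sit.

Methylsulfanyl differs from isopropoxy in both its sulfur and its fewer heavy atoms, and the compounds shown do not separate the two; methoxy or ethylsulfanyl at this position would bear on that. The other step in the set cannot be read, so nothing yet shows how far this position tolerates other groups.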